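The source may report more compounds than this note shows. Statements on the series, on what has been measured and on what is new or still open speak of the compounds shown alone.

Measured compounds:
- Compound 1, `O=C(Nc1ccccc1)c1cc(Oc2ccc(/C=C/c3ccccn3)cc2)ccn1`: 19100 nM
- Compound 2, `O=C(NCc1ccccc1)c1cc(Oc2ccc(/C=C/c3ccccn3)cc2)ccn1`: 18800 nM

In a functional assay on A549 cells (Homo sapiens) for antiproliferative activity, read by CCK-8 assay, with a stated time of 48 h (on this read-out higher numbers stand for weaker inhibition and lower numbers for stronger inhibition), compound 1 gives 19100 nM, the highest of the two numbers shown, although compound 2 with 18800 nM is within the scatter of it. Among the compounds with values here, the one measured step, a 1.0-fold lower number from compound 1 to compound 2 (0.01 log units; within the scatter), concerns the same amide-type nitrogen and shows that exchanging phenyl for benzyl there leaves the read-out unchanged. Compound 3, `O=C(c1cc(Oc2ccc(/C=C/c3ccccn3)cc2)ccn1)N1CCCC1`, has not yet been measured in this assay. It differs from compound 1 in that (pyrrolidin-1-yl in place of anilino on a carbonyl carbon). Within the data shown here, this change also sits on the amide carbonyl, so the step from compound 1 to compound 2 is the only guide, and it was flat. Among the measured compounds shown here, no measured compound lacks the hydrogen-bond donor at this position, so the data give no direct reading for that. Compound 3 is therefore expected to show no step beyond the scatter, a 1.0-fold higher number from compound 1 to compound 3 (0.02 log units; within the scatter). The estimated value of compound 3 is 20000 nM, within 8000 nM to 50000 nM.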

Compound 3, half-maximal inhibitory concentration: 15600 nM
Compound 3: middle estimate off by 1.3-fold (0.11 log units), on the high side; measured number inside the range.
By their numbers in this assay, from the lowest: compounds 3, 2 and 1 (each within the scatter of the next).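

In this assay, pyrrolidin-1-yl in place of anilino on the carbonyl carbon gives a 1.2-fold lower number from compound 1 to compound 3 (0.09 log units; within the scatter), and pyrrolidin-1-yl in place of benzylamino gives a 1.2-fold lower number from compound 2 to compound 3 (0.08 log units; within the scatter). The donor-free compound 3 thus stays within the scatter of both compounds that carry the amide hydrogen, so at this position neither that hydrogen nor a six-membered aromatic ring of carbon only is needed to keep the read-out where it stands. Nothing available explains why the number stays flat across these three groups.

On these data alone, whether any group on this carbonyl carbon can move the number beyond the scatter remains open, for example a morpholine ring, a piperazine ring or a longer alkyl chain on the amide nitrogen. The compounds shown also leave open how the read-out responds to changes elsewhere in the shared core.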